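The source may hold more compounds than are shown below. What is called first, only, known or untested is meant among the compounds shown, and "the series" means these compounds.

Measured so far in a functional assay on HT-29 cells (Homo sapiens) for cytotoxicity, read by MTT assay, with a stated time of 24 h; a higher number here means a weaker inhibitor, a lower number a stronger inhibitor:

compound 1 `O=C(O)c1ccc(CN2C(=O)S/C(=C\c3cccnc3)C2=O)cc1`: 90000 nM
compound 2 `Cc1ccc(/C=C2\SC(=O)N(Cc3ccc(C(=O)O)cc3)C2=O)cc1`: 72000 nM

Both numbers sit within the scatter of each other: the step of a 1.3-fold lower number from compound 1 to compound 2 (0.10 log units; within the scatter) is too small to read as a real difference, and compound 1, with 90000 nM in this assay, is not separated from compound 2 on the numbers shown.

Compound 3 `COc1ccc(/C=C2\SC(=O)N(Cc3ccc(C(=O)O)cc3)C2=O)cc1` is not yet measured. Against compound 1 the change is 4-methoxyphenyl in place of pyridin-3-yl on a double-bonded chain carbon bound to a double-bonded ring carbon. For the measured compounds named here, the only measured step that bears on it is a 1.3-fold lower number from compound 1 to compound 2 (0.10 log units; within the scatter), which swaps one aromatic group for another at the same place and stays within the scatter. Going by the values given here, one more aryl exchange at that position therefore gives no reason, on these numbers, to expect a step beyond the scatter in this assay, in either direction; with only one comparable step, the range is kept wide.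

Compound 3 is expected near 75000 nM in this assay, between 35000 nM and 160000 nM. The estimated step of a 1.2-fold lower number from compound 1 to compound 3 (0.08 log units; within the scatter) is expected to remain within the scatter.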

Compound 3, half-maximal inhibitory concentration: 44000 nM
For compound 3 the middle estimate is 1.7-fold (0.23 log units) above the measured one; the measured number falls inside the stated range.
By their numbers in this assay, from the lowest: compounds 3, 2 and 1 (each within the scatter of the next, the first and the last beyond it).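

In this assay, this position now gives its first step beyond the scatter, though a modest one: 4-methoxyphenyl in place of pyridin-3-yl on a double-bonded chain carbon bound to a double-bonded ring carbon gives a 2.0-fold lower number from compound 1 to compound 3 (0.31 log units; beyond the scatter) on the shared core. Methoxy in place of methyl on an aromatic carbon is not resolved (a 1.6-fold lower number from compound 2 to compound 3 (0.21 log units; within the scatter)), so the two compounds carrying a substituted carbon-only aromatic ring cannot be ranked, and only compound 3, not compound 2, is separated from compound 1. No measured property bears on why the 4-methoxyphenyl exchange clears the scatter while the 4-methylphenyl exchange does not.

As far as these compounds go, it remains open whether a dimethylamino group or a fluorine in place of the methoxy would move the number further from that of compound 1 or leave it within the scatter of compound 3. From the compounds shown here alone, all three compounds keep the same carboxylic acid, so the effect of an amide or a nitrile in its place on this cytotoxicity read-out also remains open.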